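Phenyl for methylfuran on a shared core

The source may report more compounds than this note shows. Statements on the series, on what has been measured and on what is new or still open speak of the compounds shown alone.

Going by the values given here, in a functional assay on Ehrlich cells (Mus musculus) for cytotoxicity, tested at 50 ug/mL (a higher number here means a stronger effect of the compound at the concentration tested, a lower number a weaker effect), compound 2 `COc1cc(N2C(N)=C(C#N)C(c3ccc(C)o3)C3=C2CC(C)(C)CC3=O)cc(OC)c1OC` gives 41%, the higher of the two numbers measured; compound 1 `COc1cc(N2C(N)=C(C#N)C(/C=C/c3ccccc3)C3=C2CC(C)(C)CC3=O)cc(OC)c1OC` gives 30%, and a number 11 percentage points higher from compound 1 to compound 2 (beyond the scatter) was the only step seen. Compound 3 `COc1cc(N2C(N)=C(C#N)C(c3ccccc3)C3=C2CC(C)(C)CC3=O)cc(OC)c1OC` differs from compound 2 by phenyl in place of 5-methylfuran-2-yl on a saturated ring carbon. Among the compounds with values here, no measured step touches a phenyl at this saturated ring carbon, so that single modest step offers little guidance. The account therefore expects no change beyond the scatter, a number 6 percentage points lower from compound 2 to compound 3 (within the scatter), and estimates compound 3 at 35%, within 18% to 52%.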

Compound 3, a percentage reported as activity, at one concentration (the size of the read-out at that concentration, not a potency): 8%
The estimate for compound 3 lay 27 percentage points above the measured number; the measured number lies below the stated range.
By their numbers in this assay, from the lowest: compound 3; then compound 1; then compound 2.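

In this assay this saturated ring carbon proves sensitive to the exact ring it carries: there is a number 33 percentage points lower from compound 2 to compound 3 (beyond the scatter) even though 5-methylfuran-2-yl and phenyl have the same count of heavy atoms. Phenyl also falls short of 2-phenylethenyl, with a number 22 percentage points lower from compound 1 to compound 3 (beyond the scatter) and so compound 3 stands lowest of the three. Nothing available bears on why this exchange lowers the number. Still open, on these data alone, is whether the ring oxygen or the methyl of 5-methylfuran-2-yl accounts for the difference, and how a thiophene or a pyridine would read at this carbon.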